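Iodo-to-dimethylcarbamoyl swap on the five-membered ring of compound 1

The source may hold more compounds than are shown below. What is called first, only, known or untested is meant among the compounds shown, and "the series" means these compounds.

Of the compounds shown here, two have numbers so far. Compound 1 `O=C(CCc1ccc(Oc2ccccc2)cc1)c1ncc(I)o1` gives 10 nM in an assay for inhibition of Fatty-acid amide hydrolase 1 (Rattus norvegicus) (a higher number here means a weaker inhibitor, a lower number a stronger inhibitor), and compound 2 `O=C(CCc1ccc(COc2ccccc2)cc1)c1ncc(I)o1` gives 4 nM. Compound 1 thus stands with the highest of the two numbers; its nearest neighbour is compound 2, and the step of a 2.5-fold lower number from compound 1 to compound 2 (0.40 log units; beyond the scatter) is a modest one, brought about by phenoxymethyl in place of phenoxy on an aromatic carbon.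

Compound 3 `CN(C)C(=O)c1cnc(C(=O)CCc2ccc(Oc3ccccc3)cc2)o1` has not yet been measured. It departs from compound 1 at a different spot: dimethylcarbamoyl in place of iodo on an aromatic carbon. Within the data shown here, no measured step touches the five-membered aromatic ring, so the single measured step, which concerns the other end of the molecule, gives no direct guide here. On the scant data, only a modest change from compound 1 in either direction is expected in this assay, with the larger group most likely to cost some potency, so the step of a 2.5-fold higher number from compound 1 to compound 3 (0.40 log units; beyond the scatter) is estimated. The inhibition constant of compound 3 is therefore estimated at 25 nM, within a range of 5 nM to 120 nM.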

Compound 3, inhibition constant: 5.4 nM
Estimate against measurement, compound 3: 4.6-fold (0.67 log units) above; the measured number falls inside the stated range.
By their numbers in this assay, from the lowest: compounds 2, 3 and 1 (each within the scatter of the next, the first and the last beyond it).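

In this assay, dimethylcarbamoyl in place of iodo on an aromatic carbon next to the ring oxygen gives a 1.9-fold lower number from compound 1 to compound 3 (0.27 log units; within the scatter), so the two compounds cannot be told apart in this read-out. Iodo is thus not required at this position for a number of this size, and a larger group carrying a carbonyl is accepted on the same core. Nothing available on these compounds accounts for this outcome.

Open, on these data alone, is whether the tolerance extends to other groups at this position, such as a carboxylic acid, a methyl ester, an unsubstituted carboxamide or an aminomethyl group. Also open is whether dimethylcarbamoyl on the five-membered aromatic ring combines with phenoxymethyl at the far end of the molecule, as that pairing lies outside the compounds shown.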